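A Fluorophenyl Swap in a Series That Sits at the Limit

The source may report more compounds than this note shows. Statements on the series, on what has been measured and on what is new or still open speak of the compounds shown alone.

Compound 1 `O=S(=O)(Nc1ccc2oc(-c3ccccc3)nc2c1)c1cccc(C(F)(F)F)c1` gives > 63000 nM, which is a limit of the assay and not a number.
Compound 2 `O=S(=O)(Nc1ccc(-c2nc3ccccc3o2)cc1)c1ccccc1Cl` gives > 63000 nM, also a limit of the assay.
Compound 3 `COc1ccccc1S(=O)(=O)Nc1ccc2oc(-c3ccccc3)nc2c1` gives > 63000 nM, again a limit of the assay.

All three values come from an assay on isolated protein for inhibition of malate dehydrogenase, mitochondrial (Sus scrofa), with stated times of 45 min and 30 min; a lower number here means a stronger inhibitor, a higher number a weaker inhibitor. Compound 2 therefore stands nowhere in particular: it sits where every measured compound sits, with no number of its own, since (the limit of > 63000 nM in this assay, at which 3 of the 3 values shown sit).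

Compound 4 `O=S(=O)(Nc1ccc(-c2nc3ccccc3o2)cc1)c1ccc(F)cc1` has not yet been measured. It differs from compound 2 in one place: 4-fluorophenyl in place of 2-chlorophenyl on a sulfonyl sulfur. Among the compounds with values here, no measured step between compounds differing in one place exists here, so the expectation rests on the limits alone. In this assay the expected step is a step that the limit leaves unreadable from compound 2 to compound 4, no more than the usual scatter. Compound 4 is estimated at 100000 nM, with a range from 40000 nM to 300000 nM, most likely reported once more only as a limit.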

Compound 4, half-maximal inhibitory concentration: > 63000 nM
Compound 4: a limit, no number; the forecaster's own chance of this, stated with the estimate: 85%; the middle value does not contradict the limit.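

No step can be read from compound 2 to compound 4, since both values are limits and not numbers: the limit of > 63000 nM in this assay, at which 4 of the 4 values shown sit.

The compounds shown leave open whether any structure of this kind gives a measurable inhibitory concentration.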